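The compounds below may be only part of what the source reports. "The series", "measured", "known", "first", "only" and "open" are said of these compounds alone.

Measured so far in a physicochemical assay for lipophilicity; a lower number here means a more polar compound, a higher number a more lipophilic compound:
- compound 1 `CCOC(=O)CC1CCC2(CC1)OOCCCOO2` gives 2.2
- compound 2 `O=C(CC1CCC2(CC1)OOCCCOO2)N1CCOCC1` gives 1.16
- compound 3 `FC(F)(F)c1ccc(CC2CCC3(CC2)OOCCCOO3)cc1` gives 4.79

Compound 3 stands highest of the three (4.79), and compound 1 and compound 2 both lie lower, beyond the scatter. Next comes compound 4 `CS(=O)(=O)c1ccc(CC2CCC3(CC2)OOCCCOO3)cc1` with the change methylsulfonyl in place of trifluoromethyl on an aromatic carbon in which methylsulfonyl replaces trifluoromethyl on an aromatic carbon, para to a large group. Going by the values given here, no measured step covers this exchange. Among the compounds with values here, the only step available is a number 1.04 log units lower from compound 1 to compound 2 (beyond the scatter) (morpholin-4-yl in place of ethoxy on a carbonyl carbon). That step is large, but it lies at another place and involves other groups, so it bears on the present change only loosely. In this assay a downward step beyond the scatter is expected, and it is expected to be larger than that one. The estimated step is a number 2.39 log units lower from compound 3 to compound 4 (beyond the scatter). The expected value for compound 4 is 2.4 (estimated range 1.8 to 3).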

Compound 4, partition coefficient: 2.65
Compound 4: middle estimate off by 0.25 log units, on the low side, and the stated range covers the measured number.
By their numbers in this assay, from the lowest: compound 2; then compound 1; then compound 4; then compound 3.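

In this assay, the aromatic carbon that carries trifluoromethyl in compound 3 proves sensitive to its substituent: methylsulfonyl in that place gives a number 2.14 log units lower from compound 3 to compound 4 (beyond the scatter) in the read-out. Going by these compounds alone, the earlier compounds offered only a change on a carbonyl carbon, a number 1.04 log units lower from compound 1 to compound 2 (beyond the scatter) for that exchange, so this is the first step read on the aromatic ring. Both groups count 4 heavy atoms, and only methylsulfonyl carries hydrogen-bond acceptors, so a large step here comes with no change in heavy-atom count. No measurement in hand explains the size of this step.

Open, from the compounds shown here alone, is how this aromatic carbon responds to other groups, such as a carboxylic acid, an amine or a nitrile. Also open, going by these compounds, is whether the same exchange gives a similar step elsewhere on the aromatic ring.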